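Benzyl for cyclohexyl on an aromatic nitrogen, second core

The source may report more compounds than this note shows. Statements on the series, on what has been measured and on what is new or still open speak of the compounds shown alone.

Measured in a functional assay on UACC-62 cells (Homo sapiens) for inhibition, read by sulforhodamine B assay, with a stated time of 48 h, tested at 10 uM; a higher number here means more inhibition at the concentration tested (going by the name of the read-out), a lower number less inhibition:

compound 1 `O=Cc1ccc(-c2cn3ccnc3c(-c3ccc4ncn(C5CCCCC5)c4c3)n2)cc1` gives 37.1%
compound 2 `O=Cc1ccc(-c2cn3ccnc3c(-c3ccc4ncn(Cc5ccccc5)c4c3)n2)cc1` gives 37.1%
compound 3 `c1cn2cc(-c3ccc4c(c3)ncn4C3CCCCC3)nc(-c3ccc4ncn(C5CCCCC5)c4c3)c2n1` gives 29.3%

Compound 1 and compound 2 share one core and differ only by benzyl in place of cyclohexyl on an aromatic nitrogen; in this assay this gives no change at the digits printed from compound 1 to compound 2 (within the scatter). Compound 3 carries a different core; how the core of compound 3 differs from the core of compound 1 is not broken down here, and its value sits within the scatter of both compound 1 and compound 2.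

Compound 4 `c1ccc(Cn2cnc3ccc(-c4nc(-c5ccc6c(c5)ncn6C5CCCCC5)cn5ccnc45)cc32)cc1` is not yet measured. It stands to compound 3 as compound 2 stands to compound 1: benzyl in place of cyclohexyl on an aromatic nitrogen. The place of the change is the same in both pairs, so this is the same change. Because no change at the digits printed from compound 1 to compound 2 (within the scatter) showed no movement, the expected step is a number 0.3 percentage points lower from compound 3 to compound 4 (within the scatter). Compound 4 is estimated at 29%, expected between 15% and 44%.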

Compound 4, a percentage reported as inhibition, at one concentration (the size of the read-out at that concentration, not a potency): -31.2%
Beside the measured number, compound 4's estimate is 60.2 percentage points above it; measured number below the stated range.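

In this assay, benzyl in place of cyclohexyl on an aromatic nitrogen does not behave alike on the two cores: the same change on two cores in this assay, no change at the digits printed (within the scatter) from compound 1 to compound 2 and a number 60.5 percentage points lower (beyond the scatter) from compound 3 to compound 4, 60.5 percentage points apart, beyond the scatter of two such steps. On the second core the change gives a number 60.5 percentage points lower from compound 3 to compound 4 (beyond the scatter), so the result on one core cannot be carried over to the other in this series. These two pairs do not show which part of the cores accounts for the difference, or how the change would run on any further core.

Left open is how other groups on that aromatic nitrogen, such as a longer chain, an amine or a carboxylic acid, would read on each core. Also open, from the compounds shown here alone, is whether the large step depends on the remaining cyclohexyl of compound 4.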